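Hydrazide series: cytotoxicity expectation for compound 3

A few compounds are considered here, and "the series" means these few. Any claim that something is new, unique, unknown or untested is made for them only; others in the source may bear on it.

The series shares the core of compound 1 `COc1cc(NC(C)CCCNC(=O)/C=C/c2ccccc2)c2ncccc2c1`. In an ADME assay on L6 cells (Rattus norvegicus) for cytotoxicity, read by resazurin assay, with a stated time of 70 h (a lower number here means a stronger inhibitor, a higher number a weaker inhibitor), compound 1 gives 18500 nM. Compound 2 `COc1cc(NC(C)CCCNC(=O)NNC(=O)/C=C/c2ccc(Cl)cc2)c2ncccc2c1` holds the lowest of the two numbers in this assay at 7300 nM, with compound 1 standing beyond the scatter from it. Compound 3 `COc1cc(NC(C)CCCNC(=O)NNC(=O)Nc2ccc(C(F)(F)F)cc2)c2ncccc2c1` differs from compound 2 by (4-(trifluoromethyl)phenyl)amino in place of 2-(4-chlorophenyl)ethenyl on a carbonyl carbon. For the measured compounds named here, no measured pair carries this change, so its direction is unanchored; a modest move toward a weaker number, or none beyond the scatter, is expected, the step of a 1.4-fold higher number from compound 2 to compound 3 (0.14 log units; within the scatter) being the estimate. Compound 3 is expected to give about 10000 nM, within 3500 nM to 30000 nM.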

Compound 3, half-maximal inhibitory concentration: 14900 nM
Compound 3: middle estimate off by 1.5-fold (0.17 log units), on the low side; low and high end bracket the measured number.
By their numbers in this assay, from the lowest: compound 2; then compounds 3 and 1 (each within the scatter of the next).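

On a carbonyl carbon whose other neighbour is an amide-type nitrogen, (4-(trifluoromethyl)phenyl)amino in place of 2-(4-chlorophenyl)ethenyl gives a 2.0-fold higher number from compound 2 to compound 3 (0.31 log units; beyond the scatter) in this assay, so this position responds, modestly, to the change. The double bond leaves and a hydrogen-bond donor enters while the aromatic ring stays, and this one step cannot separate those changes. Nothing measured here accounts for the step.

Open, as far as these compounds go, is how a carboxylic acid or an amine in place of the trifluoromethyl would read. From the compounds shown here alone, a plain phenylamino group at this carbonyl carbon is also open.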